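The compounds below may be only part of what the source reports. "The series", "measured", "known", "first", "only" and "open" are said of these compounds alone.

Compound 1 `Cn1ccc2c(Oc3ccc(NC(=O)c4cc5cccnc5n(-c5ccccc5)c4=O)cc3)ccnc21`, compound 2 `Cn1ccc2c(Oc3ccc(NC(=O)c4cc5cccnc5n(-c5ccc(Br)cc5)c4=O)cc3)ccnc21` and compound 3 `Cn1ccc2c(Oc3ccc(NC(=O)c4cc5cccnc5n(-c5ccc(Br)cc5F)c4=O)cc3)ccnc21` were tested in a functional assay on A549 cells (Homo sapiens) for antiproliferative activity, read by MTT assay, with a stated time of 72 h; on this read-out higher numbers stand for weaker inhibition and lower numbers for stronger inhibition. There compound 1 gives 850 nM, compound 2 gives 680 nM and compound 3 gives 1630 nM. The step of a 1.3-fold lower number from compound 1 to compound 2 (0.10 log units; within the scatter) stays inside the scatter, as does a 1.9-fold higher number from compound 1 to compound 3 (0.28 log units; within the scatter), whereas a 2.4-fold higher number from compound 2 to compound 3 (0.38 log units; beyond the scatter) goes beyond it.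

Compound 4 `Cn1ccc2c(Oc3ccc(NC(=O)c4cc5cccnc5n(-c5ccccc5)c4=O)cc3F)ccnc21` has not been measured. It differs from compound 1 by fluoro in place of hydrogen on an aromatic carbon. The same kind of change separates compound 3 from compound 2, (fluoro in place of hydrogen on an aromatic carbon), and there it made the step of a 2.4-fold higher number from compound 2 to compound 3 (0.38 log units; beyond the scatter). The two cores differ by hydrogen in place of bromo on an aromatic carbon. The surroundings of the place are not identical: in compound 3 the fluoro sits meta to a bromo group, in compound 4 meta to a large group, so the change is the same kind of change rather than the same change.

Resting on the step of a 2.4-fold higher number from compound 2 to compound 3 (0.38 log units; beyond the scatter), compound 4 is expected to show a step of about a 1.6-fold higher number from compound 1 to compound 4 (0.22 log units; within the scatter). The estimate for compound 4 is 1400 nM, between 600 nM and 3200 nM.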

Compound 4, half-maximal inhibitory concentration: 430 nM
Compound 4: middle estimate off by 3.3-fold (0.51 log units), on the high side; the measured number lies below the stated range.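

In this assay, fluoro in place of hydrogen on an aromatic carbon did not carry over as a fixed step from one core to the other: the same change on two cores in this assay, a 2.4-fold higher number (0.38 log units; beyond the scatter) from compound 2 to compound 3 and a 2.0-fold lower number (0.30 log units; within the scatter) from compound 1 to compound 4, 4.7-fold (0.68 log units) apart, beyond the scatter of two such steps. The new step, a 2.0-fold lower number from compound 1 to compound 4 (0.30 log units; within the scatter), stays inside the scatter on its own, so the rise seen with compound 3 did not recur with compound 4, yet no gain can be claimed for compound 4 either. For the compounds shown here, with only one pair for each core, and the fluoro at a different place in each pair, this shows that the earlier step cannot simply be transferred, but not whether the core or the place of the fluoro sets the difference.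

The compounds shown leave open what the same fluoro, placed as in compound 4, would do on the bromo-bearing core of compound 2, which would separate core from place. They also leave open whether chloro, methyl or methoxy at that place would track with fluoro.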